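Dropping the benzyl amide: what a bare acid may give

A few compounds are considered here, and "the series" means these few. Any claim that something is new, unique, unknown or untested is made for them only; others in the source may bear on it.

Two compounds carry a shared core in which a carbobenzyloxy-protected leucine is joined to an aminobutyric unit that ends in a ketone bearing one further carbonyl group. In an assay on isolated protein (Oryctolagus cuniculus) for inhibition of Calpain-2 catalytic subunit (Homo sapiens), at pH 8.0 (a higher number here means a weaker inhibitor, a lower number a stronger inhibitor), compound 1 `CCCCOC(=O)C(=O)C(CC)NC(=O)C(CC(C)C)NC(=O)OCc1ccccc1` gives 400 nM, and compound 2 `CCC(NC(=O)C(CC(C)C)NC(=O)OCc1ccccc1)C(=O)C(=O)NCc1ccccc1` gives 22 nM. Going by the values given here, compound 2 holds the lowest of the two numbers; its nearest neighbour is compound 1, and the one measured step, an 18-fold lower number from compound 1 to compound 2 (1.26 log units; beyond the scatter), shows that the group on the last carbonyl carbon changes the result strongly. Compound 3 `CCC(NC(=O)C(CC(C)C)NC(=O)OCc1ccccc1)C(=O)C(=O)O` differs from compound 2 in exactly that place: hydroxy in place of benzylamino on a carbonyl carbon. Among the compounds with values here, no measured step involves a hydroxy group here, so the direction rests on the weight of the single step seen. Since the benzylamino group is lost, a rise in the number is expected for compound 3 in this assay, a step of a 9.1-fold higher number from compound 2 to compound 3 (0.96 log units; beyond the scatter), giving an estimated 200 nM with a range from 40 nM to 1000 nM.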

Compound 3, inhibition constant: 22 nM
For compound 3 the middle estimate is 9.1-fold (0.96 log units) above the measured one; the whole stated range lies above it.
By their numbers in this assay, from the lowest: compounds 2 and 3 (each within the scatter of the next); then compound 1.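

In this assay, the benzylamino group turns out not to be needed at this carbonyl carbon: replacing it with hydroxy removes the aromatic ring and gives no change at the digits printed from compound 2 to compound 3 (within the scatter). Removing the butyl group from the oxygen of the ester gives an 18-fold lower number from compound 1 to compound 3 (1.26 log units; beyond the scatter), so two very different groups, benzylamino and hydroxy, give matching numbers here, while butoxy stands apart with the weaker result. Nothing available here explains why these groups behave as they do.

From the compounds shown here alone, it remains open whether a small amide group, such as plain amino or methylamino, would match benzylamino and hydroxy at this place. It is also unknown whether a shorter alkoxy group, such as methoxy, would give a number closer to that of butoxy or to those of the other two groups.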